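A Second Chloro Added to a Cytotoxic Dienone

The source may report more compounds than this note shows. Statements on the series, on what has been measured and on what is new or still open speak of the compounds shown alone.

Measured compounds:
compound 1 `CC1=C(/C=C/C(=O)/C=C/c2ccc(Cl)cc2)C(C)(C)CCC1`: 52300 nM
compound 2 `CC1=C(/C=C/C(=O)/C=C/c2ccc(F)cc2)C(C)(C)CCC1`: 7400 nM

In a functional assay on IMR-32 cells (Homo sapiens) for cytotoxicity, read by sulforhodamine B assay, with a stated time of 48 h (a higher number here means a weaker inhibitor, a lower number a stronger inhibitor), compound 1 gives 52300 nM, the highest of the two numbers. The nearest number belongs to compound 2, at 7400 nM, and the step between them is a 7.1-fold lower number from compound 1 to compound 2 (0.85 log units; beyond the scatter). Compound 3 `CC1=C(/C=C/C(=O)/C=C/c2ccc(Cl)c(Cl)c2)C(C)(C)CCC1` differs from compound 1 by chloro in place of hydrogen on an aromatic carbon, ortho to a chloro group and meta to a large group. For the measured compounds named here, the one measured step swaps a halogen for another; none adds a halogen, so it offers no direction for this change. Compound 3 is therefore expected near 40000 nM in this assay, between 12000 nM and 130000 nM, a step of a 1.3-fold lower number from compound 1 to compound 3 (0.12 log units; within the scatter) that is estimated to stay within the scatter.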

Compound 3, half-maximal inhibitory concentration: 72400 nM
The estimate for compound 3 lay 1.8-fold (0.26 log units) below the measured number; measured number inside the range.
By their numbers in this assay, from the lowest: compound 2; then compounds 1 and 3 (each within the scatter of the next).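

Placing chloro on an aromatic carbon, ortho to a chloro group and meta to a large group, gives a 1.4-fold higher number from compound 1 to compound 3 (0.14 log units; within the scatter) in this assay. So at this position, a second chloro on the core of compound 1 produces no difference that can be told from the scatter, unlike the halogen swap seen earlier. No available evidence bears on this result.

On these data alone, what methoxy or an amine at this same place would give remains open. So does whether a second halogen on compound 2 would behave the same way.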